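The source may report more compounds than this note shows. Statements on the series, on what has been measured and on what is new or still open speak of the compounds shown alone.

Measured so far in a functional assay on HeLa cells (Homo sapiens) for cytotoxicity, read by sulforhodamine B assay, with a stated time of 48 h; on this read-out lower numbers stand for stronger inhibition and higher numbers for weaker inhibition:
Compound 1 `CC(=O)OC[C@H]1O[C@@H](n2cc(Cn3cc(/C=C/C(=O)c4cccnc4)c4ccccc43)nn2)[C@H](OC(C)=O)[C@@H](OC(C)=O)[C@@H]1OC(C)=O` — compound 1 sits at the assay limit > 200000 nM.
Compound 2 `CC(=O)OC[C@H]1O[C@@H](n2cc(CN3C(=O)/C(=C\C=C\c4ccccc4)c4ccccc43)nn2)[C@H](OC(C)=O)[C@@H](OC(C)=O)[C@@H]1OC(C)=O` — compound 2 gives 98100 nM.
Compound 3 `CC(=O)OC[C@H]1O[C@@H](n2cc(CN3C(=O)/C(=C/C=C/c4ccccc4)c4ccccc43)nn2)[C@H](OC(C)=O)[C@@H](OC(C)=O)[C@@H]1OC(C)=O` — compound 3 sits at the assay limit > 100000 nM.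

Compound 3 is therefore reported only as a limit in this assay, and two of the three values shown are limits rather than numbers (the limit of > 100000 nM in this assay, at which 1 of the 3 values shown sits, (the limit of > 200000 nM in this assay, at which 1 of the 3 values shown sits)). Among the compounds with values here, the one step that can be read between measured compounds is an at least 1.0-fold higher number from compound 2 to compound 3 (0.00 log units; that floor lies within the scatter), which rests on the fact that compounds 2 and 3 differ only in the configuration as drawn and carries no information about a change of substituent.

Compound 4 `CC(=O)OC[C@H]1O[C@@H](n2cc(CN3C(=O)/C(=C/c4ccco4)c4ccccc43)nn2)[C@H](OC(C)=O)[C@@H](OC(C)=O)[C@@H]1OC(C)=O` differs from compound 3 by furan-2-yl in place of 2-phenylethenyl on a double-bonded chain carbon bound to a double-bonded ring carbon. Within the data shown here, no measured step exchanges one group on that chain carbon for another, so the step from compound 3 to compound 4 has no direct precedent. All three measured compounds sit at or near the top of the range in this assay, and nothing shown suggests that the change to furan-2-yl would move compound 4 away from that region. The expected step of a number no higher from compound 3 to compound 4 (the limit leaves the size open) is accordingly small and within the scatter. Compound 4 is estimated at 100000 nM in this assay, with a range from 30000 nM to 300000 nM, and most likely reported again only as a limit.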

Compound 4, half-maximal inhibitory concentration: 29900 nM
Estimate against measurement, compound 4: 3.3-fold (0.52 log units) above; the measured number lies below the stated range.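

The group on a double-bonded chain carbon bound to a double-bonded ring carbon affects the read-out in this assay: furan-2-yl in place of 2-phenylethenyl gives an at least 3.3-fold lower number from compound 3 to compound 4 (0.52 log units; beyond the scatter), whereas the earlier step changed only the configuration as drawn and its floor stayed within the scatter. As far as these compounds go, the value of compound 3 is a limit, so this step is only a floor and its full size stays open: the limit of > 100000 nM in this assay, at which 1 of the 4 values shown sits. The entering group has fewer heavy atoms, a five-membered ring with a hetero atom and a hydrogen-bond acceptor, and it lacks the double bond of the leaving group outside aromatic rings, but this single step cannot separate these differences and gives no cause for the lower number.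

Open, from the compounds shown here alone, is whether the lower number needs the furan oxygen, the five-membered ring or only the loss of the ethenyl link, which a directly attached phenyl or a thiophen-2-yl at the same chain carbon would help to separate. Also open, going by these compounds, is how a basic group such as an amine at that carbon would read in this assay.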